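Methoxy for Trifluoromethyl: A Solubility Step Awaiting Measurement

The source may hold more compounds than are shown below. What is called first, only, known or untested is meant among the compounds shown, and "the series" means these compounds.

Three compounds share one core and were tested in a physicochemical assay for solubility, read by HPLC, with a stated time of 4 h, at pH 7; on this read-out lower numbers stand for lower solubility and higher numbers for higher solubility. Compound 1 `C[C@]1(COc2ccc(S(=O)(=O)N3CCOCC3)cc2)Cn2cc([N+](=O)[O-])nc2O1` gives 20 ug/mL in this assay. Compound 2 `C[C@]1(COc2ccc(N3CCN(S(=O)(=O)c4ccc(C(F)(F)F)cc4)CC3)cc2)Cn2cc([N+](=O)[O-])nc2O1` returns only a limit of this assay, < 1 ug/mL, not a number. Compound 3 `C[C@]1(COc2ccc(-n3cc(COc4ccc(OC(F)(F)F)cc4)nn3)cc2)Cn2cc([N+](=O)[O-])nc2O1` likewise returns only a limit in this assay, < 1 ug/mL. Compound 2 therefore stands at the floor of the numbers shown, the place described by the limit of < 1 ug/mL in this assay, at which 2 of the 3 values shown sit, while compound 1 alone gives a measurable reading.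

Compound 4 `COc1ccc(S(=O)(=O)N2CCN(c3ccc(OC[C@@]4(C)Cn5cc([N+](=O)[O-])nc5O4)cc3)CC2)cc1` has not yet been measured. It differs from compound 2 in one place: methoxy in place of trifluoromethyl on an aromatic carbon. Within the data shown here, no two measured compounds here differ in a single place, so no measured step can be borrowed for this change. In this assay compound 4 is expected to give about 2 ug/mL, with a likely span from 0.5 ug/mL to 8 ug/mL. That amounts to an expected step of an at least 2.0-fold higher number from compound 2 to compound 4 (0.30 log units; that floor lies within the scatter), a modest rise, and a reading that again stops at the limit would not be surprising.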

Compound 4, solubility: < 1 ug/mL
Compound 4: no number, only a limit; the forecaster's own chance of this, stated with the estimate: 40%; at least 2.0-fold (0.30 log units) between middle value and limit.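

Compound 2 and compound 4 both return only a limit in this assay, not a number, and no step can be read between them. The compounds shown leave open whether methoxy in place of trifluoromethyl on this aromatic carbon changes the reading at all, and in which direction.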